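Rearranging the bicyclic ether of compound 1

The source may hold more compounds than are shown below. What is called first, only, known or untested is meant among the compounds shown, and "the series" means these compounds.

Measured compounds:
- compound 1 `CN(c1ccc(Oc2ncnc3ccsc23)cc1)c1nccc(N2CCCC2)n1`: 38%
- compound 2 `CN(c1ccc(Oc2ncnc3ccsc23)cc1)c1nccc(N2CCc3ccccc3C2)n1`: 30.2%
- compound 3 `CN(c1ccc(Oc2ncnc3ccsc23)cc1)c1nccc(N2CCCCC2)n1`: 49.7%

In a functional assay on MDA-MB-231 cells (Homo sapiens) for inhibition, read by MTT assay, with a stated time of 72 h, tested at 20 uM (a higher number here means more inhibition at the concentration tested (going by the name of the read-out), a lower number less inhibition), compound 1 gives 38%. On these three numbers compound 1 stands second highest. Its value and that of compound 2 lie within the scatter of each other, as the step of a number 7.8 percentage points lower from compound 1 to compound 2 (within the scatter) shows, so no order between the two can be read. Compound 3 stands higher, by a number 11.7 percentage points higher from compound 1 to compound 3 (beyond the scatter), and also above compound 2, by a number 19.5 percentage points higher from compound 2 to compound 3 (beyond the scatter). All three measured steps swap the amine ring on the aromatic carbon.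

Compound 4 `CN(c1ccc(Oc2ncnc3sccc23)cc1)c1nccc(N2CCCC2)n1` has not yet been measured. It differs from compound 1 at another place: a group of 9 heavy atoms (6 carbon, 2 nitrogen, 1 sulfur; one five-membered aromatic ring with 1 hetero atom, one six-membered aromatic ring with 2 hetero atoms) in place of a group of 9 heavy atoms (6 carbon, 2 nitrogen, 1 sulfur; one five-membered aromatic ring with 1 hetero atom, one six-membered aromatic ring with 2 hetero atoms), on an oxygen on an aromatic ring. The two compounds hold the same atoms, joined differently. Among the measured compounds shown here, none of the measured steps touches this part of the molecule, so the three steps give no direct guide. With the rest unchanged, the step of no change at the digits printed from compound 1 to compound 4 (within the scatter) is expected to stay within the scatter in this assay. Compound 4 is therefore estimated at 38%, with a range from 20% to 56%.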

Compound 4, a percentage reported as inhibition, at one concentration (the size of the read-out at that concentration, not a potency): 31%
Estimate against measurement, compound 4: 7 percentage points above; low and high end bracket the measured number.
By their numbers in this assay, from the lowest: compounds 2, 4 and 1 (each within the scatter of the next); then compound 3.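

In this assay, among the compounds shown here, the first change to the bicyclic group on the oxygen keeps the same atoms but joins them differently, and it gives a number 7 percentage points lower from compound 1 to compound 4 (within the scatter). For the compounds shown here, this position can therefore be rearranged in this way without a difference that can be read in this assay, at least with pyrrolidin-1-yl as the amine ring, and the only steps beyond the scatter remain those that swap the amine ring. No measurement of any property of these two bicyclic groups bears on this result.

On these data alone, it remains open whether the rearranged group would behave the same way alongside piperidin-1-yl, the amine ring of compound 3. As far as these compounds go, it is also open how the number would respond if a different group, such as a simple phenyl or pyridyl ring, stood on that oxygen.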